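The source may hold more compounds than are shown below. What is called first, only, known or untested is meant among the compounds shown, and "the series" means these compounds.

Measured in a functional assay on K562 cells (Homo sapiens) for cytotoxicity, read by MTT assay, with a stated time of 48 h; on this read-out lower numbers stand for stronger inhibition and higher numbers for weaker inhibition:
- Compound 1 `Cc1ccccc1CN1CCN(C(=O)CN[C@H]2CCN(S(=O)(=O)Cc3ccccc3)C2)CC1`: 10200 nM
- Compound 2 `O=C(CN[C@H]1CCN(S(=O)(=O)Cc2ccccc2)C1)N1CCN(Cc2ccccc2Cl)CC1`: 9000 nM
- Compound 3 `O=C(CN[C@H]1CCN(S(=O)(=O)Cc2ccccc2)C1)N1CCN(Cc2cccc(Cl)c2)CC1`: 8600 nM

Compound 3, at 8600 nM, cannot be told apart from the other two compounds, as all three values lie within the usual scatter of one another. The next compound, compound 4 `O=C(CN[C@H]1CCN(S(=O)(=O)Cc2ccccc2)C1)N1CCN(Cc2ccc(Cl)cc2)CC1`, carries 4-chlorophenyl in place of 3-chlorophenyl on a saturated chain carbon bound to an amine nitrogen in a ring.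

For the measured compounds named here, the closest precedent is the exchange of 2-chlorophenyl for 3-chlorophenyl at that same place, which gave a 1.0-fold lower number from compound 2 to compound 3 (0.02 log units; within the scatter). The other two measured steps are just as small: a 1.1-fold lower number from compound 1 to compound 2 (0.05 log units; within the scatter) and a 1.2-fold lower number from compound 1 to compound 3 (0.07 log units; within the scatter). Going by the values given here, each of the three exchanges on this aromatic group stayed within the scatter, so no step beyond the scatter is expected here, although only three compounds support this expectation.

The estimated step is a 1.0-fold higher number from compound 3 to compound 4 (0.01 log units; within the scatter).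

Compound 4 is expected at 8800 nM, with an estimated range of 5500 nM to 14000 nM.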

Compound 4, half-maximal inhibitory concentration: 9200 nM
Compound 4: middle estimate off by 1.0-fold (0.02 log units), on the low side; measured number inside the range.
By their numbers in this assay, from the lowest: compounds 3, 2, 4 and 1 (each within the scatter of the next).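

In this assay, the 4-chlorophenyl group completes the set of three chlorophenyl placements, and moving the chlorine again produces no step beyond the scatter, whether starting from the 3-chlorophenyl group (a 1.1-fold higher number from compound 3 to compound 4 (0.03 log units; within the scatter)) or from the 2-chlorophenyl group (a 1.0-fold higher number from compound 2 to compound 4 (0.01 log units; within the scatter)). The comparison with the 2-methylphenyl group gives the same picture (a 1.1-fold lower number from compound 1 to compound 4 (0.04 log units; within the scatter)), so all four aromatic groups at this place on a saturated chain carbon bound to an amine nitrogen in a ring cannot be told apart. No measurement is available to explain this flat result.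

The compounds shown leave open whether a carboxylic acid or an amine on this aromatic ring would shift the number beyond the scatter. They also leave open whether any change elsewhere in the shared core would do so.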